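The compounds below may be only part of what the source reports. "The series", "measured", "known", "first", "only" and "open" are said of these compounds alone.

Compound 1 `O=C(O)Cc1sc(C(c2ccc(F)cc2)c2ccc(F)cc2)nc1-c1ccco1` gives 140 nM in an in vitro functional assay on HEK285-7 cells for antagonist activity at prostaglandin D2 receptor 2 (Homo sapiens), read by BRET and beta-arrestin recruitment; on this read-out higher numbers stand for weaker inhibition and lower numbers for stronger inhibition.
Compound 2 `O=C(O)Cc1sc(C(c2ccc(F)cc2)c2ccc(F)cc2)nc1-c1cc(F)nc(F)c1` gives 110 nM in this assay.
Compound 3 `CN(C)c1cc(-c2nc(C(c3ccc(F)cc3)c3ccc(F)cc3)sc2CC(=O)O)ccn1` gives only a limit, > 100000 nM, in this assay.

Compound 3 thus stands at the upper edge of what this assay reports; its value is a limit, not a number, as seen in the limit of > 100000 nM in this assay, at which 1 of the 3 values shown sits. The steps leading to it were large: an at least 710-fold higher number from compound 1 to compound 3 (2.85 log units; beyond the scatter) and an at least 900-fold higher number from compound 2 to compound 3 (2.95 log units; beyond the scatter). Compound 4 `O=C(O)Cc1sc(C(c2ccc(F)cc2)c2ccc(F)cc2)nc1-c1ccnc(N2CCCC2)c1` differs from compound 3 by pyrrolidin-1-yl in place of dimethylamino on an aromatic carbon. For the measured compounds named here, no measured step covers this exchange; the two large steps show only that 2-(dimethylamino)pyridin-4-yl coincided with the loss of activity, and compound 4 keeps a closely related group. The expected step is therefore a number no higher from compound 3 to compound 4 (the limit leaves the size open), none beyond the scatter. Compound 4 is estimated at 100000 nM, between 20000 nM and 300000 nM, most likely reported again as a limit.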

Compound 4, half-maximal inhibitory concentration: > 100000 nM
Compound 4 ended at the assay's limit (the forecaster's own chance of this, stated with the estimate: 70%); the middle value lies on the limit itself.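

Replacing dimethylamino with pyrrolidin-1-yl does not bring activity back: there is an at least 900-fold higher number from compound 2 to compound 4 (2.95 log units; beyond the scatter) and an at least 710-fold higher number from compound 1 to compound 4 (2.85 log units; beyond the scatter). The values of compound 3 and compound 4 are both limits, so the step between them cannot be read. Two different amino groups next to the ring nitrogen now give the same outcome, so the loss is not particular to dimethylamino: the limit of > 100000 nM in this assay, at which 2 of the 4 values shown sit.

On these data alone, whether a plain amine or a methoxy group at this place would keep activity stays open. So does how far beyond the limit compound 3 and compound 4 really lie.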